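The compounds below may be only part of what the source reports. "The series", "measured", "known", "first", "only" and "open" are said of these compounds alone.

Values in an ADME assay on THP-1 cells (Homo sapiens) for cytotoxicity, read by trypan blue exclusion, with a stated time of 24 h; a higher number here means a weaker inhibitor, a lower number a stronger inhibitor:
- compound 1 `N#C[Se]Cc1ccc([N+](=O)[O-])cc1`: 16800 nM
- compound 2 `N#C[Se]Cc1ccc(C(F)(F)F)cc1`: 19800 nM
- compound 3 `CSc1ccc(C[Se]C#N)cc1`: 17000 nM

Compound 3 cannot be separated from the other two compounds, as a 1.0-fold higher number from compound 1 to compound 3 (0.01 log units; within the scatter) and a 1.2-fold lower number from compound 2 to compound 3 (0.07 log units; within the scatter). The three values therefore give no meaningful order.

The next compound is compound 4 `N#C[Se]Cc1ccc(C#N)cc1`, with cyano in place of methylsulfanyl on an aromatic carbon, para to a group of 4 heavy atoms: cyano in place of methylsulfanyl on an aromatic carbon.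

Going by the values given here, no measured step involves cyano, so the evidence is indirect. The closest precedents are the exchanges at this same place among the other groups. Besides the two steps above, the third is a 1.2-fold higher number from compound 1 to compound 2 (0.07 log units; within the scatter). Among the compounds with values here, all three measured exchanges stay within the scatter, and no compound in this small set goes against that. Within the data shown here, the set is only three compounds, and a new group could still depart from it.

In this assay, no step beyond the scatter is therefore expected. The expected step is a 1.1-fold higher number from compound 3 to compound 4 (0.02 log units; within the scatter). For compound 4 the estimated value is 18000 nM. The expected range for compound 4 runs from 10000 nM to 30000 nM.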

Compound 4, half-maximal inhibitory concentration: 7970 nM
For compound 4 the middle estimate is 2.3-fold (0.35 log units) above the measured one; the measured number lies below the stated range.
By their numbers in this assay, from the lowest: compound 4; then compounds 1, 3 and 2 (each within the scatter of the next).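

In this assay, going by these compounds alone, this position on the aromatic ring is no longer silent: cyano is the first group here to move the number beyond the scatter, with a 2.1-fold lower number from compound 3 to compound 4 (0.33 log units; beyond the scatter), a 2.5-fold lower number from compound 2 to compound 4 (0.40 log units; beyond the scatter) and a 2.1-fold lower number from compound 1 to compound 4 (0.32 log units; beyond the scatter), all of modest size. Compound 4 therefore sits apart at the low end, while nitro, trifluoromethyl and methylsulfanyl remain inseparable, so the exchanges at this place are not uniformly without effect, and among these four groups only cyano departs. Methylsulfanyl and cyano match in heavy atoms, hydrogen-bond donors and hydrogen-bond acceptors, so those counts do not separate compound 3 from compound 4, and nothing measured in this set accounts for the difference.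

Whether the lower number is particular to cyano remains open, as the compounds shown include no amine, carboxylic acid or halogen at this place. Also open, as far as these compounds go, is whether the step from cyano would persist with a longer chain in place of the methylene linking the ring to the selenocyanate.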